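A few compounds are considered here, and "the series" means these few. Any claim that something is new, unique, unknown or untested is made for them only; others in the source may bear on it.

Of the compounds shown here, three built on one shared core have been tested in a functional assay on LNCaP cells (Homo sapiens) for antiproliferative activity, read by propidium iodide staining, with a stated time of 96 h; a lower number here means a stronger inhibitor, a higher number a weaker inhibitor. Compound 1 `CC(O)(COc1ccc(S(F)(F)(F)(F)F)cc1)C(=O)Nc1cc(C(F)(F)F)cc(C(F)(F)F)c1` gives 1900 nM in this assay. Compound 2 `CC(O)(COc1cccc(S(F)(F)(F)(F)F)c1)C(=O)Nc1cc(C(F)(F)F)cc(C(F)(F)F)c1` gives 3000 nM, and the gap between compound 1 and compound 2 lies within the scatter. Compound 3 `CC(O)(COc1cccc(C(F)(F)C(F)(F)F)c1)C(=O)Nc1cc(C(F)(F)F)cc(C(F)(F)F)c1` gives 4400 nM. Compound 2 and compound 3 differ in a single place: a group of 7 heavy atoms (2 carbon, 5 fluorine; no ring) in place of a group of 6 heavy atoms (5 fluorine, 1 sulfur; no ring), on an aromatic carbon. That change made a 1.5-fold higher number from compound 2 to compound 3 (0.17 log units; within the scatter).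

Compound 1 and compound 2 are made of the same atoms joined differently; the difference between the two cores is not broken down here. The unmeasured compound 4 `CC(O)(COc1ccc(C(F)(F)C(F)(F)F)cc1)C(=O)Nc1cc(C(F)(F)F)cc(C(F)(F)F)c1` stands to compound 1 as compound 3 stands to compound 2: a group of 7 heavy atoms (2 carbon, 5 fluorine; no ring) in place of a group of 6 heavy atoms (5 fluorine, 1 sulfur; no ring), on an aromatic carbon. The surroundings are not identical, since in compound 2 and compound 3 the changed group sits meta to a large group, whereas in compound 1 and compound 4 it sits para to a large group, so this is the same kind of change rather than the same change.

Within the data shown here, only one earlier example of this change is available, so the expectation rests on that single step. The step from compound 1 to compound 4 is expected to be about a 1.5-fold higher number from compound 1 to compound 4 (0.17 log units; within the scatter) in this assay, matching the earlier 1.5-fold higher number from compound 2 to compound 3 (0.17 log units; within the scatter). Compound 4 is therefore estimated at 2800 nM, with a range from 1400 nM to 5600 nM.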

Compound 4, half-maximal inhibitory concentration: 2700 nM
For compound 4 the middle estimate is 1.0-fold (0.02 log units) above the measured one, and the stated range covers the measured number.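

In this assay, putting 1,1,2,2,2-pentafluoroethyl in place of the group of 5 fluorine atoms on sulfur, on the core of compound 1, gives a 1.4-fold higher number from compound 1 to compound 4 (0.15 log units; within the scatter). Set beside the earlier example of this swap, the new step shows that the change carried over from one core to the other with much the same small size: the same change on two cores in this assay, a 1.5-fold higher number (0.17 log units; within the scatter) from compound 2 to compound 3 and a 1.4-fold higher number (0.15 log units; within the scatter) from compound 1 to compound 4, 1.0-fold (0.01 log units) apart, within the scatter of two such steps. Among these compounds, each step lies within the scatter, however, so this agreement does not show that the swap truly alters activity on either core, only that the two groups could not be told apart here, and two cores say nothing firm about how the swap would behave on a third.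

The compounds shown leave open how other groups would behave in the same place on the ring, such as a nitrile, a chlorine, an amine or a carboxylic acid, and whether any of them would move the number beyond the scatter. They also leave open whether the swap would stay this small if the two trifluoromethyl groups on the other ring were replaced, for example by a single nitrile, and whether it would look the same outside this assay.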